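From hexyl to benzyl on a shared core

The source may hold more compounds than are shown below. What is called first, only, known or untested is meant among the compounds shown, and "the series" means these compounds.

Compound 1 `CCCCCCn1cnc2c(Nc3ccc(O)cc3)nc(N[C@H]3CC[C@H](N)CC3)nc21` gives 190 nM
Compound 2 `CCCCCCn1cnc2c(Nc3cccc(Cl)c3)nc(N[C@H]3CC[C@H](N)CC3)nc21` gives 310 nM

In a functional assay on EOL1 cells (Homo sapiens) for inhibition, read by fluorescence, with a stated time of 72 h (on this read-out lower numbers stand for stronger inhibition of growth and higher numbers for weaker inhibition of growth), compound 2 cannot be told apart from compound 1, as a 1.6-fold higher number from compound 1 to compound 2 (0.21 log units; within the scatter) shows. Compound 3 `N[C@H]1CC[C@H](Nc2nc(Nc3cccc(Cl)c3)c3ncn(Cc4ccccc4)c3n2)CC1` carries phenyl in place of pentyl on a saturated chain carbon bound to an aromatic nitrogen. Going by the values given here, the only measured step, a 1.6-fold higher number from compound 1 to compound 2 (0.21 log units; within the scatter), lies elsewhere, on a nitrogen on an aromatic ring, and so gives no guide to this change. With compound 2 at 310 nM as the anchor, the expected step is a 1.1-fold higher number from compound 2 to compound 3 (0.05 log units; within the scatter), with none foreseen beyond the scatter. Compound 3 is estimated at 350 nM (range 90 nM to 1300 nM).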

Compound 3, concentration for 50% growth inhibition: 380 nM
Estimate against measurement, compound 3: 1.1-fold (0.04 log units) below, and the stated range covers the measured number.
By their numbers in this assay, from the lowest: compounds 1, 2 and 3 (each within the scatter of the next).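

Replacing pentyl with phenyl on a saturated chain carbon bound to an aromatic nitrogen gives a 1.2-fold higher number from compound 2 to compound 3 (0.09 log units; within the scatter) in this assay. Compound 1 and compound 2 both carry hexyl, so they said nothing about this position; compound 3 shows that, with 3-chlorophenyl held fixed, hexyl and benzyl cannot be told apart here. Nothing available explains why the two groups read alike. The compounds shown leave open whether an amine, a carboxylic acid or a longer chain at this position would read differently. They also leave open whether benzyl would match hexyl with the 4-hydroxyphenyl group of compound 1.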